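From 3-ethylphenyl to 2,5-dimethylphenyl on a sulfonamide

A few compounds are considered here, and "the series" means these few. Any claim that something is new, unique, unknown or untested is made for them only; others in the source may bear on it.

Compound 1 `CCc1cccc(NS(=O)(=O)c2ccc(N3CCNC3=O)cc2)c1`: 200 nM
Compound 2 `COc1cc(NS(=O)(=O)c2ccc(N3CCNC3=O)cc2)cc(OC)c1OC`: 23 nM

Of the compounds shown here, two have been measured in a functional assay on CCRF-CEM cells (Homo sapiens) for antiproliferative activity, read by sulforhodamine B assay, with a stated time of 48 h; a higher number here means a weaker inhibitor, a lower number a stronger inhibitor. Compound 1 stands at the higher of the two numbers, which makes it the weaker inhibitor of the pair. Compound 2 gives a lower number, and the gap between the two lies beyond the usual scatter of repeated measurements.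

The next compound is compound 3 `Cc1ccc(C)c(NS(=O)(=O)c2ccc(N3CCNC3=O)cc2)c1`, which carries 2,5-dimethylphenyl in place of 3-ethylphenyl on a sulfonamide nitrogen. The two hold the same atoms, joined differently. For the measured compounds named here, no measured step shows the effect of such a change, so no step beyond the scatter is expected in this assay, and compound 1 at 200 nM serves as the reference. The estimated step is a 1.1-fold lower number from compound 1 to compound 3 (0.05 log units; within the scatter). Compound 3 is expected at 180 nM, within an estimated range of 60 nM to 600 nM.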

Compound 3, half-maximal inhibitory concentration: 74 nM
Compound 3: the middle estimate sits 2.4-fold (0.39 log units) above what was measured; measured number inside the range.
By their numbers in this assay, from the lowest: compound 2; then compound 3; then compound 1.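

In this assay, rearranging the same atoms from 3-ethylphenyl to 2,5-dimethylphenyl on the sulfonamide nitrogen gives a 2.7-fold lower number from compound 1 to compound 3 (0.43 log units; beyond the scatter) and this modest step lies beyond the scatter. It shows that this position responds to how the carbon atoms are arranged on the phenyl ring, even though the two groups match in heavy atoms, ring type, hydrogen-bond donors and acceptors, and charge. No measurement at hand accounts for the step.

The compounds shown leave open whether a single methyl on the phenyl ring would give a similar number, and how chlorine, an amine or a carboxylic acid would fare at this position. They also leave open whether the step from 3-ethylphenyl to 2,5-dimethylphenyl would hold in other cell lines.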